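Methoxy for bromo on the benzylamine of compound 3

A few compounds are considered here, and "the series" means these few. Any claim that something is new, unique, unknown or untested is made for them only; others in the source may bear on it.

Measured compounds:
compound 3 `O=S(=O)(NCCCNCc1ccc(Br)cc1)c1cc(C(F)(F)F)cc(C(F)(F)F)c1`: 2300 nM
compound 1 `O=S(=O)(NCCCCNCc1ccc(Br)cc1)c1cc(C(F)(F)F)cc(C(F)(F)F)c1`: 2100 nM
compound 2 `O=S(=O)(NCCCNCc1ccccc1)c1cc(C(F)(F)F)cc(C(F)(F)F)c1`: 11000 nM

In a functional assay on MIA PaCa-2 cells (Homo sapiens) for inhibition, read by MTT assay, with a stated time of 72 h (on this read-out higher numbers stand for weaker inhibition of growth and lower numbers for stronger inhibition of growth), compound 3 stands close to compound 1 and well apart from compound 2: a 1.1-fold higher number from compound 1 to compound 3 (0.04 log units; within the scatter), whereas a 4.8-fold lower number from compound 2 to compound 3 (0.68 log units; beyond the scatter). Compound 4 `COc1ccc(CNCCCNS(=O)(=O)c2cc(C(F)(F)F)cc(C(F)(F)F)c2)cc1` differs from compound 3 by methoxy in place of bromo on an aromatic carbon. Among the measured compounds shown here, no measured pair compares methoxy with bromo directly; the only step at that aromatic carbon, a 4.8-fold lower number from compound 2 to compound 3 (0.68 log units; beyond the scatter), shows that taking bromo away raises the number modestly. With nothing to say how methoxy compares with either, a rise in the same direction but of smaller size is expected, a 2.2-fold higher number from compound 3 to compound 4 (0.34 log units; beyond the scatter). Compound 4 is therefore estimated at 5000 nM, with a range from 2000 nM to 13000 nM.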

Compound 4, concentration for 50% growth inhibition: 2500 nM
The estimate for compound 4 lay 2.0-fold (0.30 log units) above the measured number; the range from low to high includes it.
By their numbers in this assay, from the lowest: compounds 1, 3 and 4 (each within the scatter of the next); then compound 2.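

In this assay, methoxy at this aromatic carbon does what bromo does, with a 1.1-fold higher number from compound 3 to compound 4 (0.04 log units; within the scatter) and, against hydrogen, a 4.4-fold lower number from compound 2 to compound 4 (0.64 log units; beyond the scatter), so the drop in the number seen with bromo is not confined to that one group. The 4-methoxybenzyl compound also reads level with the bromo compound on the chain of compound 1, with a 1.2-fold higher number from compound 1 to compound 4 (0.08 log units; within the scatter). Nothing available here bears on why methoxy and bromo read alike. As far as these compounds go, whether fluoro, nitrile or a carboxylic acid at this carbon would also match hydrogen's gap stays open, as does how methoxy behaves on the chain of compound 1.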